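The source may report more compounds than this note shows. Statements on the series, on what has been measured and on what is new or still open speak of the compounds shown alone.

The three measured compounds share one core and differ only in the group carried on the aromatic oxygen. In a functional assay (aorta) with Rattus norvegicus as the target (on this read-out higher numbers stand for higher potency (the scale is a negative logarithm) and lower numbers for lower potency), compound 1 `CC1(C)C=C(n2ccccc2=O)c2cc(OCC(=O)c3ccccc3)ccc2O1` gives 5.05. In this assay compound 2 `CC1(C)C=C(n2ccccc2=O)c2cc(OCC(=O)c3ccc(F)cc3)ccc2O1` gives 4.63, and compound 3 `CC1(C)C=C(n2ccccc2=O)c2cc(OC(=O)Nc3ccccc3)ccc2O1` gives 5.3. Compound 3 stands highest of the three numbers: the step of a number 0.25 log units higher from compound 1 to compound 3 (within the scatter) is within the scatter, so compound 1 and compound 3 cannot be told apart, whereas the step of a number 0.67 log units higher from compound 2 to compound 3 (beyond the scatter) lies beyond it.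

Compound 4 `CC1(C)C=C(n2ccccc2=O)c2cc(OC(=O)Nc3ccccc3C(F)(F)F)ccc2O1` is made from compound 3 by trifluoromethyl in place of hydrogen on an aromatic carbon. Going by the values given here, no measured step puts a trifluoromethyl anywhere, and none touches the phenylcarbamoyl ring itself. Among the compounds with values here, the only measured step that resembles it is a halogen on an aromatic carbon of the pendant ring, a number 0.42 log units lower from compound 1 to compound 2 (beyond the scatter), which went down by a modest amount. That single step sits on a different group, so it gives only weak guidance; this assay is therefore expected to show for compound 4 at most a small downward step, a number 0.20 log units lower from compound 3 to compound 4 (within the scatter), and quite possibly nothing beyond the scatter. Compound 4 is estimated at 5.1, with a range from 4.5 to 5.7.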

Compound 4, logarithm of the reciprocal of the active concentration, log(1/C): 5.58
The estimate for compound 4 lay 0.48 log units below the measured number; the measured number falls inside the stated range.
By their numbers in this assay, from the lowest: compound 2; then compounds 1, 3 and 4 (each within the scatter of the next, the first and the last beyond it).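

On the phenylcarbamoyl ring, in this assay, trifluoromethyl in place of hydrogen on an aromatic carbon, ortho to a large group, gives a step that stays inside the scatter: a number 0.28 log units higher from compound 3 to compound 4 (within the scatter) in the measured read-out. This shows that the ring of the phenylcarbamoyl group can carry a substituent of this size at this place with no change that can be told apart, whereas the only earlier ring substitution, fluoro on the pendant ring of the benzoylmethyl series, gave a number 0.42 log units lower from compound 1 to compound 2 (beyond the scatter) on a different group, so the two steps do not add up to one rule for substituents on the pendant ring. Nothing measured here offers an explanation for this outcome.

The compounds shown leave open whether this tolerance belongs to trifluoromethyl alone or extends to other groups on the same aromatic carbon, such as a methoxy, an amine or a carboxylic acid. They also leave open whether a trifluoromethyl on another carbon of that ring would stay as close to the unsubstituted phenylcarbamoyl compound, and whether a fluoro on this ring would repeat the step seen in the benzoylmethyl pair.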